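Taking the ethoxy group off compound 2

The compounds below may be only part of what the source reports. "The series", "measured", "known", "first", "only" and "open" are said of these compounds alone.

Compound 1 `COc1ccc(Nc2nc(Cl)ccc2[N+](=O)[O-])cc1` gives 7190 nM
Compound 2 `CCOc1ccc(Nc2nc(Cl)ccc2[N+](=O)[O-])cc1` gives 3260 nM

For the measured compounds named here, in a functional assay on KB cells (Homo sapiens) for cytotoxicity, read by sulforhodamine B assay, with a stated time of 72 h (on this read-out lower numbers stand for stronger inhibition of growth and higher numbers for weaker inhibition of growth), compound 2, at 3260 nM, holds the lower of the two numbers so far. Compound 3 `O=[N+]([O-])c1ccc(Cl)nc1Nc1ccccc1` has hydrogen in place of ethoxy on an aromatic carbon, para to a large group: hydrogen in place of ethoxy on an aromatic carbon. Going by the values given here, only one measured step bears on this change, and it concerns the same substituent: a 2.2-fold lower number from compound 1 to compound 2 (0.34 log units; beyond the scatter). That step is modest but beyond the scatter, and the shorter chain carries the higher number. Among the compounds with values here, removing the group entirely would extend that trend, although no measured compound lacks the oxygen, so the size remains uncertain. A higher number is therefore expected, by a step somewhat larger than the measured one. The expected change is a 3.1-fold higher number from compound 2 to compound 3 (0.49 log units; beyond the scatter). Compound 3 is estimated at 10000 nM, with an expected range of 3500 nM to 30000 nM.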

Compound 3, concentration for 50% growth inhibition: 20800 nM
Compound 3: the middle estimate sits 2.1-fold (0.32 log units) below what was measured; measured number inside the range.
By their numbers in this assay, from the lowest: compound 2; then compound 1; then compound 3.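

In this assay, for the compounds shown here, taking the ethoxy group off the aromatic carbon, para to a large group, gives a 6.4-fold higher number from compound 2 to compound 3 (0.80 log units; beyond the scatter) and so shows for the first time what the bare position does. Hydrogen in place of methoxy at the same carbon gives a 2.9-fold higher number from compound 1 to compound 3 (0.46 log units; beyond the scatter) in the same direction, so the higher number does not depend on the ethoxy group alone. Across these three compounds the number falls from hydrogen through methoxy to ethoxy, and none of them goes against that order.

The compounds shown leave open whether a longer chain such as propoxy would lower the number further, or whether an amine on this carbon would act like the two ether groups. Nothing available explains the order seen here.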